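Swapping the aryl group beside the amide: from nitrile to fluorine

The source may hold more compounds than are shown below. What is called first, only, known or untested is meant among the compounds shown, and "the series" means these compounds.

Compound 2 `N#Cc1cccc(C(=O)Nc2c(C(O)(C(F)(F)F)C(F)(F)F)ccc3ccccc23)c1` gives the lower of the two numbers recorded in an assay on LtK cells with ATP-sensitive inward rectifier potassium channel 11 (Homo sapiens) as the target (on this read-out higher numbers stand for an effect only at larger amounts of compound and lower numbers for an effect already at smaller amounts), namely 12 nM. Among the measured compounds shown here, its only neighbour, compound 1 `Cc1ccccc1C(=O)Nc1c(C(O)(C(F)(F)F)C(F)(F)F)ccc2ccccc12`, gives 5550 nM in this assay, and the single recorded step is a 460-fold lower number from compound 1 to compound 2 (2.67 log units; beyond the scatter), which shows that changing the aryl group on the carbonyl carbon can move the number a long way. Compound 3 `O=C(Nc1c(C(O)(C(F)(F)F)C(F)(F)F)ccc2ccccc12)c1ccc(F)cc1` differs from compound 2 by 4-fluorophenyl in place of 3-cyanophenyl on a carbonyl carbon. For the measured compounds named here, no measured step covers this exact exchange, so the direction rests on the loss of the nitrile and on the size of the step from compound 1 to compound 2. Compound 3 is therefore expected to give a higher number than compound 2, estimated at 300 nM in this assay, with a plausible range from 30 nM to 3000 nM. The expected step of a 25-fold higher number from compound 2 to compound 3 (1.40 log units; beyond the scatter) is uncertain because of the size of a 460-fold lower number from compound 1 to compound 2 (2.67 log units; beyond the scatter).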

Compound 3, half-maximal effective concentration: 70 nM
For compound 3 the middle estimate is 4.3-fold (0.63 log units) above the measured one; measured number inside the range.
By their numbers in this assay, from the lowest: compound 2; then compound 3; then compound 1.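

The nitrile is not required for a low number at this position: with 4-fluorophenyl on the carbonyl carbon, the result is a 5.8-fold higher number from compound 2 to compound 3 (0.77 log units; beyond the scatter) in this assay and remains far from the high number of compound 1. The other step, a 79-fold lower number from compound 1 to compound 3 (1.90 log units; beyond the scatter) with 4-fluorophenyl in place of 2-methylphenyl, shows that the large drop seen earlier is not unique to 3-cyanophenyl. Nothing available explains why these aryl groups give such different numbers.

3-cyanophenyl and 4-fluorophenyl differ both in the group carried and in its numbered place on the ring, and the compounds shown do not separate those two changes. Going by these compounds, how 4-cyanophenyl, 3-fluorophenyl, or a phenyl ring carrying an amine or a carboxylic acid would read at this position also remains open.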